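The source may hold more compounds than are shown below. What is called first, only, known or untested is meant among the compounds shown, and "the series" means these compounds.

In a functional assay on HCT-116 cells (Homo sapiens) for inhibition, read by MTT assay, with a stated time of 48 h (a lower number here means a stronger inhibitor, a higher number a weaker inhibitor), compound 3 `COc1cc(-c2nnc(SCc3ccccc3)n2-c2ccc(N(C)C)cc2)cc(OC)c1OC` gives 54000 nM and lies within the scatter of compound 1 `COc1ccc(-n2c(SCc3ccccc3)nnc2-c2cc(OC)c(OC)c(OC)c2)cc1` at 42400 nM on the shared core. For the measured compounds named here, the step between these two reads a 1.3-fold higher number from compound 1 to compound 3 (0.11 log units; within the scatter) and is the only exchange of dimethylamino in place of methoxy on an aromatic carbon. Compound 2 `COc1ccc(-n2c(SCC(=O)c3ccccc3)nnc2-c2cc(OC)c(OC)c(OC)c2)cc1` has no number, only a limit: > 60000 nM.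

The change to compound 4 `COc1cc(-c2nnc(SCC(=O)c3ccccc3)n2-c2ccc(N(C)C)cc2)cc(OC)c1OC` is benzoyl in place of phenyl on a saturated chain carbon bound to a sulfur. Going by the values given here, the one measured step of this kind is an at least 1.4-fold higher number from compound 1 to compound 2 (0.15 log units; that floor lies within the scatter), which is a floor set by the limit of > 60000 nM in this assay, at which 1 of the 3 values shown sits, and not a measured size. The direction seen for compound 2 is expected to hold for compound 4, giving a higher number in this assay by an amount the data do not fix. The estimated change is a 1.4-fold higher number from compound 3 to compound 4 (0.14 log units; within the scatter). Compound 4 may well give only a limit. Compound 4 is estimated at 75000 nM, with an expected range from 45000 nM to 150000 nM.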

Compound 4, half-maximal inhibitory concentration: 42500 nM
Compound 4: middle estimate off by 1.8-fold (0.25 log units), on the high side, outside the stated range (below it).
By their numbers in this assay, from the lowest: compounds 1, 4 and 3 (each within the scatter of the next). At a limit, above all of these: compound 2.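

In this assay, benzoyl in place of phenyl on a saturated chain carbon bound to a sulfur now has a step with a measured value at both ends: a 1.3-fold lower number from compound 3 to compound 4 (0.10 log units; within the scatter). As far as these compounds go, on the core of compound 3 this change therefore stays within the scatter, while the reading on the core of compound 1 remains open-ended: the same change on two cores in this assay, an at least 1.4-fold higher number (0.15 log units; that floor lies within the scatter) from compound 1 to compound 2 and a 1.3-fold lower number (0.10 log units; within the scatter) from compound 3 to compound 4; the limit leaves it open whether they differ. Dimethylamino in place of methoxy on an aromatic carbon gains a second reading, an at least 1.4-fold lower number from compound 2 to compound 4 (0.14 log units; that floor lies within the scatter), which rests on a limit: the same change on two cores in this assay, a 1.3-fold higher number (0.11 log units; within the scatter) from compound 1 to compound 3 and an at least 1.4-fold lower number (0.14 log units; that floor lies within the scatter) from compound 2 to compound 4; the limit leaves it open whether they differ.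

Compound 2 has only a limit, > 60000 nM, and the size of its step stays unfixed. Open too, from the compounds shown here alone, is whether a carboxylic acid, an amine or a longer chain in place of benzoyl at this carbon would move the number beyond the scatter.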